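A few compounds are considered here, and "the series" means these few. Any claim that something is new, unique, unknown or untested is made for them only; others in the source may bear on it.

Compound 1 `COc1ccc(-n2ncn(Cc3cn(Cc4cc5cc(Br)ccc5nc4Cl)nn3)c2=O)cc1`: 333 ug/mL
Compound 2 `O=c1n(Cc2cn(Cc3cc4cc(Cl)ccc4nc3Cl)nn2)cnn1-c1ccccc1`: 459 ug/mL

In an ADME assay on HEK293 cells (Homo sapiens) for cytotoxicity, read by MTT assay (a higher number here means a weaker inhibitor, a lower number a stronger inhibitor), compound 2 gives 459 ug/mL, the higher of the two numbers recorded so far. In this assay compound 1 gives 333 ug/mL, and the two values lie within the scatter of each other, so neither can be called the weaker or the stronger inhibitor. Compound 3 `O=c1n(Cc2cn(Cc3cc4cc(Br)ccc4nc3Cl)nn2)cnn1-c1ccccc1` has not yet been measured in this assay. It differs from compound 2 in one place: bromo in place of chloro on an aromatic carbon. Going by the values given here, no pair of measured compounds differs only in this way, so the size of this change cannot be read from a measured step. Compound 1, which carries the same bromo group on the same ring, gives 333 ug/mL, a number close to that of compound 2. The change from compound 2 to compound 3 is therefore expected to be no step beyond the scatter, estimated as a 1.2-fold lower number from compound 2 to compound 3 (0.07 log units; within the scatter). Compound 3 is expected to give 390 ug/mL, with a range from 220 ug/mL to 680 ug/mL.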

Compound 3, half-maximal inhibitory concentration: 1650 ug/mL
The estimate for compound 3 lay 4.2-fold (0.63 log units) below the measured number, and the stated range ends below it.
By their numbers in this assay, from the lowest: compounds 1 and 2 (each within the scatter of the next); then compound 3.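

In this assay, the position on the six-membered aromatic ring of carbon only proved sensitive to the halogen: bromo in place of chloro gives a 3.6-fold higher number from compound 2 to compound 3 (0.56 log units; beyond the scatter). With the bromo group held fixed, hydrogen in place of methoxy on an aromatic carbon also matters, giving a 5.0-fold higher number from compound 1 to compound 3 (0.70 log units; beyond the scatter). The earlier pair lay within the scatter while differing in both of these places, so that closeness concealed two separate steps, each beyond the scatter.

Nothing available explains either step. The compounds shown leave open whether the halogen step holds with methoxy present, and how fluoro or iodo at this position, or an amine in place of methoxy, would read.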